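A few compounds are considered here, and "the series" means these few. Any claim that something is new, unique, unknown or untested is made for them only; others in the source may bear on it.

Compound 1 `COC(=O)c1cccc(NC(=O)Nc2cc(C)nc3ccccc23)c1` has a single number in an ADME assay on HepG2 cells (Homo sapiens) for cytotoxicity, with a stated time of 72 h; on this read-out lower numbers stand for an effect already at smaller amounts and higher numbers for an effect only at larger amounts of compound: in this assay compound 1 gives 23000 nM. Compound 2 `Cc1cc(NC(=O)Nc2ccc(C(N)=O)cc2)c2ccccc2n1` is the other measured member of the set. In this assay compound 2 returns only a limit, > 25000 nM, and no number. Among the compounds with values here, compound 1 thus holds the only number among the two values shown, the other resting at the limit of > 25000 nM in this assay, at which 1 of the 2 values shown sits. Compound 3 `Cc1cc(NC(=O)Nc2cccc(C(C)(C)C)c2)c2ccccc2n1` is the compound still to be measured. It differs from compound 1 in one place: tert-butyl in place of methoxycarbonyl on an aromatic carbon. Within the data shown here, no two measured compounds differ in only one place, so no measured step speaks directly to this change, and what is expected rests on compound 1 and compound 2 alone. Compound 1 lies close to the value at which compound 2 gives a limit, so the step in this assay is expected to be of moderate size toward lower values, a 1.5-fold lower number from compound 1 to compound 3 (0.19 log units; within the scatter), with a fair chance that it does not exceed the scatter. Compound 3 is therefore estimated to give 15000 nM in this assay, within a range from 5000 nM to 40000 nM.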

Compound 3, half-maximal effective concentration: > 25000 nM
Compound 3 was reported as a limit (the forecaster's own chance of this, stated with the estimate: 30%); middle value at least 1.6-fold (0.22 log units) from the limit.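

In this assay, tert-butyl in place of methoxycarbonyl on an aromatic carbon gives an at least 1.0-fold higher number from compound 1 to compound 3 (0.03 log units; that floor lies within the scatter). Within the data shown here, this is the first step in the set that speaks to this position, and it shows that exchanging methoxycarbonyl, with its 2 hydrogen-bond acceptors, for tert-butyl, with 0 and the same count of 4 heavy atoms, brings no effect at smaller amounts of compound, since the result for compound 3 is a limit and not a number. With this result, most of the set now reads only as a limit rather than as a graded series of numbers: the limit of > 25000 nM in this assay, at which 2 of the 3 values shown sit.

As far as these compounds go, how far compound 3 lies past that limit stays unknown, so the step has only a floor and whether the change moves the read-out beyond the usual scatter remains open. Among these compounds, also open is what a carboxylic acid, an amine or a longer chain on this aromatic carbon would give, and whether any such group would bring a number well clear of the one compound 1 gives.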